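A Cyclopentyl Swap in a Microsomal Stability Series

This account rests on a few compounds, and the source may have more. Where it says the series, first, only, none or still open, it means among the compounds named here.

In an ADME assay on microsomes from liver (Homo sapiens) for metabolic stability, with a stated time of 30 min, tested at 1 uM (a higher number here means that more of the compound is left, a lower number that less of the compound is left), compound 1 (`CC[C@@H]1C(=O)N(C)c2cnc(-n3ccnc3-c3ccccc3)nc2N1C1CCCC1`) gives 0%, the lowest of three numbers. Compound 3 (`CCC1C(=O)N(C)c2cnc(-n3ccnc3-c3ccc(F)cc3)nc2N1c1ccc(F)cc1`) gives 47% and compound 2 (`CC[C@@H]1C(=O)N(C)c2cnc(-n3ccnc3-c3ccc(F)cc3)nc2N1C1COC1`) gives 74%. Both lie above compound 1 by more than the scatter, though each differs from it in more than one place. Compound 4 (`CC[C@@H]1C(=O)N(C)c2cnc(-n3ccnc3-c3ccccc3)nc2N1[C@H]1CCOC1`) departs from compound 1 in a single place: oxolan-3-yl in place of cyclopentyl on a nitrogen on an aromatic ring in a ring. Within the data shown here, no measured pair isolates this change, so the forecast is loose and rests on compound 2 reaching 74% with another group on that nitrogen. A sizeable rise is expected in this assay, with an estimated step of a number 35 percentage points higher from compound 1 to compound 4 (beyond the scatter). For compound 4 the estimated value is 35%, with an expected range of 10% to 62%.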

Compound 4, percent of the compound remaining: 17%
Estimate against measurement, compound 4: 18 percentage points above, and the stated range covers the measured number.
By their numbers in this assay, from the lowest: compound 1; then compound 4; then compound 3; then compound 2.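

In this assay, oxolan-3-yl in place of cyclopentyl on this nitrogen gives a number 17 percentage points higher from compound 1 to compound 4 (beyond the scatter), a modest step and the first to isolate a single change at this position. The two groups match in ring size and heavy-atom count, so exchanging one ring carbon for an oxygen is enough to move the number beyond the scatter. Nothing available explains why the number moves. From the compounds shown here alone, the opposite configuration of the oxolan-3-yl stereocentre remains open. So does the outcome with an oxan-4-yl group or a morpholine on this nitrogen.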